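A few compounds are considered here, and "the series" means these few. Any claim that something is new, unique, unknown or untested is made for them only; others in the source may bear on it.

Working notes on the series. Within the data shown here, compound 3 `CC(=O)Nc1ccc2c(c1)O[C@@H]([C@@H]1CCCN1C)CO2` gives 46000 nM in an assay on membranes from Cerebral cortex for displacement of a labelled ligand from Neuronal acetylcholine receptor; alpha4/beta2 (Rattus norvegicus), with a stated time of 5 min (on this read-out higher numbers stand for weaker inhibition and lower numbers for stronger inhibition), and stands highest of the three numbers so far; compound 2 `CN1CCC[C@H]1[C@H]1COc2ccc([N+](=O)[O-])cc2O1` is nearest, with 33000 nM, and a 1.4-fold higher number from compound 2 to compound 3 (0.14 log units; within the scatter), so the two are not separated. Compound 1 `CN1CCC[C@H]1[C@H]1COc2ccc(N)cc2O1` gives 140 nM and is furthest: a 330-fold higher number from compound 1 to compound 3 (2.52 log units; beyond the scatter), alongside a 240-fold higher number from compound 1 to compound 2 (2.37 log units; beyond the scatter). Compound 4 `CN(C)c1ccc2c(c1)O[C@@H]([C@@H]1CCCN1C)CO2` carries dimethylamino in place of acetamido on an aromatic carbon. The step from compound 1 to compound 3 bears on it directly, as acetyl on the aromatic nitrogen was lost on; compound 4 removes that acetyl but keeps two methyls on the nitrogen, so a partial return toward compound 1 is expected, not a full one. Compound 4 is therefore estimated at 2500 nM in this assay, range 500 nM to 12000 nM, meaning an expected 18-fold lower number from compound 3 to compound 4 (1.26 log units; beyond the scatter).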

Compound 4, inhibition constant: 49000 nM
Compound 4: middle estimate off by 20-fold (1.29 log units), on the low side; the whole stated range lies below it.
By their numbers in this assay, from the lowest: compound 1; then compounds 2, 3 and 4 (each within the scatter of the next).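

In this assay dimethylamino on this aromatic carbon is not separated from acetamido (a 1.1-fold higher number from compound 3 to compound 4 (0.03 log units; within the scatter)) or from nitro (a 1.5-fold higher number from compound 2 to compound 4 (0.17 log units; within the scatter)), while the step from amino remains large (a 350-fold higher number from compound 1 to compound 4 (2.54 log units; beyond the scatter)). Losing the acetyl therefore does not by itself recover the number of compound 1, and acetamido, with its hydrogen-bond donor, and dimethylamino, with none, are not separated here. Nothing at hand explains this. Still open, going by these compounds, is whether a single methyl on the nitrogen, as in methylamino, stays with compound 1 or joins compound 4. A hydroxyl at this place is equally unresolved.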